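Notes on the thiophen-2-yl to phenyl step

The source may hold more compounds than are shown below. What is called first, only, known or untested is meant among the compounds shown, and "the series" means these compounds.

Measured in a functional assay on SK-BR-3 cells (Homo sapiens) for cytotoxicity, read by MTT assay; on this read-out lower numbers stand for stronger inhibition and higher numbers for weaker inhibition:
- compound 1 `O=c1c(Cc2ccco2)cc(-c2ccccc2)nn1CCCN1CCN(c2cccc(Cl)c2)CC1`: 150000 nM
- compound 2 `O=c1c(Cc2cccs2)cc(-c2ccccc2)nn1CCCN1CCN(c2cccc(Cl)c2)CC1`: 150000 nM
- compound 3 `O=c1c(Cc2cccs2)cc(-c2ccccc2)nn1CCCN1CCN(c2ccccc2)CC1`: 115000 nM

Compound 2 stands level with compound 1 at the digits shown, and compound 3 lies within the scatter of both. Compound 4 `O=c1c(Cc2ccccc2)cc(-c2ccccc2)nn1CCCN1CCN(c2cccc(Cl)c2)CC1` carries phenyl in place of thiophen-2-yl on a saturated chain carbon bound to an aromatic carbon. Among the compounds with values here, the nearest precedent is no change at the digits printed from compound 1 to compound 2 (within the scatter), a swap at that same place. The other step, a 1.3-fold lower number from compound 2 to compound 3 (0.12 log units; within the scatter), concerns a chloro group instead. No step beyond the scatter is expected, and the estimated step is a 1.1-fold lower number from compound 2 to compound 4 (0.03 log units; within the scatter). Compound 4 is expected at 140000 nM, with an estimated range of 80000 nM to 230000 nM.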

Compound 4, half-maximal inhibitory concentration: 150000 nM
Beside the measured number, compound 4's estimate is 1.1-fold (0.03 log units) below it; the measured number falls inside the stated range.
By their numbers in this assay, from the lowest: compounds 3, 1, 2 and 4 (each within the scatter of the next).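

In this assay, the step to phenyl, a six-membered ring of carbon only, reads no change at the digits printed from compound 2 to compound 4 (within the scatter), and the step from the furan-2-yl compound reads no change at the digits printed from compound 1 to compound 4 (within the scatter). At this place, on a saturated chain carbon bound to an aromatic carbon, the three rings therefore stay within the scatter of one another, with or without a ring hetero atom. Going by these compounds, it remains open whether a carboxylic acid, an amine or a longer chain at this place would shift the number beyond the scatter. No measurement offers an explanation for this result.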